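Replacing the methylcarbamoyl group of compound 3

This account rests on a few compounds, and the source may have more. Where it says the series, first, only, none or still open, it means among the compounds named here.

- compound 1 `N#Cc1cnc(NCc2cnccc2C(F)(F)F)cc1NC[C@H]1CC[C@@H](O)CC1` gives 18%
- compound 2 `N#Cc1cnc(NCc2cnccc2C(F)(F)F)cc1N[C@H]1CC[C@@H](C(N)=O)CC1` gives 30%
- compound 3 `CNC(=O)[C@H]1CC[C@@H](Nc2cc(NCc3cnccc3C(F)(F)F)ncc2C#N)CC1` gives 53%

In an ADME assay on S9 fraction from liver (Rattus norvegicus) for metabolic stability, with a stated time of 1 h (on this read-out higher numbers stand for a more stable compound and lower numbers for a less stable compound), compound 3 stands highest of the three, and its gaps to both others lie beyond the scatter. Compound 4 `N#Cc1cnc(NCc2cnccc2C(F)(F)F)cc1N[C@H]1CC[C@@H](n2cncn2)CC1` carries 1H-1,2,4-triazol-1-yl in place of methylcarbamoyl on a saturated ring carbon and has not yet been measured.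

The closest evidence is a number 23 percentage points higher from compound 2 to compound 3 (beyond the scatter), a modest step from a change on the amide-type nitrogen alone. The changes a number 12 percentage points higher from compound 1 to compound 2 (beyond the scatter) and a number 35 percentage points higher from compound 1 to compound 3 (beyond the scatter) are modest and large, but both alter the whole substituent on the nitrogen. Among the measured compounds shown here, no measured compound carries the triazole, so no step shows its effect directly. Compound 3 holds the top value of 53%, and here the whole group changes, so a modest fall is expected rather than a further rise. The expected change is a number 11 percentage points lower from compound 3 to compound 4 (beyond the scatter), with wide uncertainty. For compound 4 the estimate is 42%, with an expected range of 20% to 66%.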

Compound 4, percent of the compound remaining: 44%
For compound 4 the middle estimate is 2 percentage points below the measured one; the measured number falls inside the stated range.
By their numbers in this assay, from the lowest: compound 1; then compound 2; then compounds 4 and 3 (each within the scatter of the next).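

In this assay the saturated ring carbon accepts an aromatic ring in place of an amide, with a number 9 percentage points lower from compound 3 to compound 4 (within the scatter) and no separation between the two groups. An amide carbonyl and amide hydrogen are therefore not needed at this position to hold the number at this level, and the rise is not confined to the methylcarbamoyl group, since the triazole also shows a number 14 percentage points higher from compound 2 to compound 4 (beyond the scatter) in place of carbamoyl. No measured property of these compounds accounts for either step.

As far as these compounds go, it remains open whether other groups on this carbon, such as a carboxylic acid, a primary amine or an imidazole ring, would stand at the same level. The compounds shown also leave open whether the arrangement of the triazole nitrogens matters, as only one triazole isomer appears among them.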